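The source may hold more compounds than are shown below. What is called first, only, known or untested is meant among the compounds shown, and "the series" means these compounds.

Measured in a functional assay on HOS cells (Homo sapiens) for antiproliferative activity, read by sulforhodamine B assay; a lower number here means a stronger inhibitor of growth, a higher number a weaker inhibitor of growth:
- compound 1 `O[C@H]1CO[C@H](COCc2ccccc2)[C@@H](OCc2ccccc2)[C@@H]1OCc1ccccc1`: 37900 nM
- compound 2 `CC[C@@H]1O[C@H](COCc2ccccc2)[C@@H](OCc2ccccc2)[C@H](OCc2ccccc2)[C@H]1O`: 34200 nM
- compound 3 `OC[C@@H]1O[C@H](COCc2ccccc2)[C@@H](OCc2ccccc2)[C@H](OCc2ccccc2)[C@H]1O`: 27300 nM

Compound 3, at 27300 nM, stands within the scatter of both other compounds, so the three form a single band of values. The next structure is compound 4 `O[C@@H]1[C@@H](OCc2ccccc2)[C@H](OCc2ccccc2)[C@@H](COCc2ccccc2)O[C@H]1CC1CCCCC1`. It carries cyclohexyl in place of hydroxy on a saturated chain carbon bound to a saturated ring carbon, which, cut one bond further out, reads hydroxymethyl to cyclohexylmethyl: cyclohexyl in place of hydroxy on a saturated chain carbon bound to a saturated ring carbon.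

The closest evidence comes from the same chain carbon, where putting hydroxy in place of methyl gave a 1.3-fold lower number from compound 2 to compound 3 (0.10 log units; within the scatter). On the saturated ring carbon, ethyl in place of hydrogen gave a 1.1-fold lower number from compound 1 to compound 2 (0.04 log units; within the scatter), and hydroxymethyl in place of hydrogen gave a 1.4-fold lower number from compound 1 to compound 3 (0.14 log units; within the scatter). All three steps are small, and so far this place has shown no response in this assay. None of them brought in a ring, however, so cyclohexyl goes beyond what was tested and the range must stay wide. No change beyond the scatter is expected, and no direction is favoured. The expected size is a 1.1-fold lower number from compound 3 to compound 4 (0.04 log units; within the scatter). The estimate for compound 4 is 25000 nM, with an expected range from 10000 nM to 60000 nM.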

Compound 4, concentration for 50% growth inhibition: 4400 nM
For compound 4 the middle estimate is 5.7-fold (0.75 log units) above the measured one, outside the stated range (below it).
By their numbers in this assay, from the lowest: compound 4; then compounds 3, 2 and 1 (each within the scatter of the next).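

In this assay this position, which had shown no response so far, does respond once a ring enters: cyclohexyl in place of hydroxy on a saturated chain carbon bound to a saturated ring carbon gives a 6.2-fold lower number from compound 3 to compound 4 (0.79 log units; beyond the scatter) and lies beyond the scatter, as does cyclohexyl in place of methyl at the same carbon, with a 7.8-fold lower number from compound 2 to compound 4 (0.89 log units; beyond the scatter) in this assay. Read against the compound with only hydrogen on the saturated ring carbon, cyclohexylmethyl gives an 8.6-fold lower number from compound 1 to compound 4 (0.94 log units; beyond the scatter) in the same assay, so compound 4 stands clearly apart from the three other compounds, which remain one band, and it holds the lowest number of the four. Nothing available accounts for this gain.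

The compounds shown leave open whether the gain needs the cyclohexyl ring itself or would also come from an open carbon chain such as hexyl at the same chain carbon, and whether a phenyl ring or a smaller cyclopentyl ring would do the same. They also leave open how an amine or a carboxylic acid carried on the cyclohexyl ring would read in this assay.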